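Halogen exchange on the 4-fluorophenyl group of compound 2

The compounds below may be only part of what the source reports. "The series", "measured", "known", "first", "only" and "open" are said of these compounds alone.

In a functional assay on HL-60 cells (Homo sapiens) for antiproliferative activity, read by MTT assay, with a stated time of 72 h (on this read-out higher numbers stand for weaker inhibition and lower numbers for stronger inhibition), compound 1 (`COc1cc(C(=O)c2sc3ccccc3c2-c2ccccc2)cc(OC)c1OC`) gives 1700 nM and compound 2 (`COc1cc(C(=O)c2sc3ccccc3c2-c2ccc(F)cc2)cc(OC)c1OC`) gives 3200 nM. Among the compounds with values here, these two values lie within the scatter of each other, so compound 2 stands level with compound 1 on the only two numbers available, and the series has no separated reference point yet.

The next compound is compound 3 (`COc1cc(C(=O)c2sc3ccccc3c2-c2ccc(Cl)cc2)cc(OC)c1OC`), with chloro in place of fluoro on an aromatic carbon, para to a large group: chloro in place of fluoro on an aromatic carbon.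

Within the data shown here, only one measured step bears on this change. It is fluoro in place of hydrogen on an aromatic carbon, a 1.9-fold higher number from compound 1 to compound 2 (0.27 log units; within the scatter), and it stays within the scatter. Among the measured compounds shown here, no chloro compound has been measured, so this single step gives only weak guidance and the range must stay wide.

No step beyond the scatter is therefore expected in this assay, and no direction is favoured with any confidence. The expected step is a 1.1-fold lower number from compound 2 to compound 3 (0.06 log units; within the scatter). For compound 3 the estimated value is 2800 nM, with an expected range of 1200 nM to 6500 nM.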

Compound 3, half-maximal inhibitory concentration: 3300 nM
Estimate against measurement, compound 3: 1.2-fold (0.07 log units) below, and the stated range covers the measured number.
By their numbers in this assay, from the lowest: compounds 1, 2 and 3 (each within the scatter of the next).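

In this assay the change from 4-fluorophenyl to 4-chlorophenyl gives a 1.0-fold higher number from compound 2 to compound 3 (0.01 log units; within the scatter) and so does not separate the two halogens at this place on the ring. Chloro in place of hydrogen at the same place gives a 1.9-fold higher number from compound 1 to compound 3 (0.29 log units; within the scatter) and thus adds a second halogen to the fluoro comparison, a 1.9-fold higher number from compound 1 to compound 2 (0.27 log units; within the scatter) so that neither halogen is separated from the unsubstituted phenyl compound on this read-out. No accompanying measurement bears on why these three numbers stand level.

Still open, going by these compounds, is whether any group at this place moves the number beyond the scatter: a methoxy group, a nitrile, an amine or a carboxylic acid would test this far more widely than an exchange among fluoro, chloro and hydrogen. The three compounds also leave open whether the level result holds on the core of compound 1 when the trimethoxyphenyl ketone part or the other ring positions are changed, since all three share those parts unchanged.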